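Branching the propoxy chain in a sulfonamide antagonist

The source may hold more compounds than are shown below. What is called first, only, known or untested is meant among the compounds shown, and "the series" means these compounds.

Compound 1, `CC(C(=O)NCc1ccc(C(F)(F)F)cc1N1CCCCCC1)c1ccc(NS(C)(=O)=O)c(F)c1`, and compound 2, `CCCOc1cc(C(F)(F)F)ccc1CNC(=O)C(C)c1ccc(NS(C)(=O)=O)c(F)c1`, share one core and differ only in the group on an aromatic carbon. In an assay on CHO cells for antagonist activity at transient receptor potential cation channel subfamily V member 1 (Homo sapiens), read by FLIPR (a higher number here means a weaker inhibitor, a lower number a stronger inhibitor), compound 1 gives 1.6 nM, and compound 2 gives 2 nM. Among the measured compounds shown here, the single step so far, a 1.3-fold higher number from compound 1 to compound 2 (0.10 log units; within the scatter), replaces azepan-1-yl with propoxy and leaves the two numbers within the usual scatter of each other, so compound 2 stands level with compound 1 on this series of two.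

Compound 3, `CC(C)COc1cc(C(F)(F)F)ccc1CNC(=O)C(C)c1ccc(NS(C)(=O)=O)c(F)c1`, keeps everything in compound 2 except for the change (methyl in place of hydrogen on a saturated chain carbon bound to two saturated chain carbons), which reads, one bond further out, as propoxy to isobutoxy. For the measured compounds named here, no measured step touches the inside of this chain; the only step known swaps a whole ring for a chain and tells nothing about branching. With no evidence for a shift either way, the expectation is a step of about a 1.1-fold higher number from compound 2 to compound 3 (0.04 log units; within the scatter), that is nothing beyond the scatter. Compound 3 is therefore estimated at 2.2 nM, with a range from 0.8 nM to 6 nM.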

Compound 3, inhibition constant: 0.8 nM
Beside the measured number, compound 3's estimate is 2.8-fold (0.44 log units) above it, within the range that was stated.
By their numbers in this assay, from the lowest: compounds 3, 1 and 2 (each within the scatter of the next, the first and the last beyond it).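

In this assay the added methyl, which turns propoxy into isobutoxy, gives a 2.5-fold lower number from compound 2 to compound 3 (0.40 log units; beyond the scatter) and so shows, though only modestly, that this chain responds to branching, something the earlier swap of a whole ring for a chain could not reveal. The isobutoxy group also holds up against the azepan-1-yl ring: a 2.0-fold lower number from compound 1 to compound 3 (0.30 log units; within the scatter) means that compound 1 and compound 3 stand level, so on this aromatic carbon a branched chain and a ring of that kind give numbers that cannot be told apart in this assay. No measurement shown here bears on what lies behind the modest step from propoxy to isobutoxy.

The compounds shown leave open whether the branch itself matters or simply the added carbon, a question that a straight butoxy chain would address. As far as these compounds go, it also remains open how far this chain can grow or change at its end, for example with a longer pentyloxy chain, a cyclopropylmethoxy group or a terminal amine.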